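The source may hold more compounds than are shown below. What is called first, only, known or untested is meant among the compounds shown, and "the series" means these compounds.

Three compounds have been measured in a functional assay on the whole organism for agonist activity, with Mus musculus as the target; on this read-out higher numbers stand for an effect only at larger amounts of compound and lower numbers for an effect already at smaller amounts:

Compound 1 `COC(=O)N(C)C(C)C#CCn1cncc1C`: > 100 mg/kg
Compound 2 `CCOC(=O)N(C)CC#CCn1cncc1C`: > 100 mg/kg
Compound 3 `CCOC(=O)N(C)C(C)C#CCn1ccnc1`: > 100 mg/kg

All three results sit at the same boundary: the limit of > 100 mg/kg in this assay, at which 3 of the 3 values shown sit. For compound 3, > 100 mg/kg is a limit of the assay and not a number.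

Compound 4 `CCOC(=O)N(C)C(C)C#CCn1cncc1C` differs from compound 3 by methyl in place of hydrogen on an aromatic carbon, 1H-imidazol-1-yl to 5-methyl-1H-imidazol-1-yl: methyl in place of hydrogen on an aromatic carbon.

Compound 1 already carries 5-methyl-1H-imidazol-1-yl, and its result is the limit > 100 mg/kg. Compound 2 carries it too, and its result is the limit > 100 mg/kg.

The expected step that the limit leaves unreadable from compound 3 to compound 4 is no larger than the usual scatter. For compound 4 the estimated value is 150 mg/kg, within an expected range of 60 mg/kg to 400 mg/kg.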

Compound 4, dose for half-maximal effect: > 100 mg/kg
Compound 4: only a limit was reported (the forecaster's own chance of this, stated with the estimate: 75%); the middle value does not contradict the limit.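

In this assay compound 4 gives > 100 mg/kg, which is a limit and not a number. No step from compound 1, compound 2 or compound 3 to compound 4 can be read, as all four results sit at one boundary: the limit of > 100 mg/kg in this assay, at which 4 of the 4 values shown sit.

The compounds shown leave open what dose any of them would need for a half-maximal effect, and whether the added methyl groups change that dose at all.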